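The compounds below may be only part of what the source reports. "The series", "measured", "known", "first", "only" and "open" are said of these compounds alone.

For the measured compounds named here, only two compounds have results so far in a functional assay on PC-3 cells (Homo sapiens) for antiproliferative activity; on this read-out lower numbers stand for stronger inhibition and higher numbers for weaker inhibition. Compound 1 `Nc1nc(=O)n([C@H]2C=C[C@@H](CO)O2)cc1Br` gives > 100000 nM, which is a limit of the assay and not a number. Compound 2 `CC(=O)OC[C@@H]1C=C[C@H](n2cc(F)c(N)nc2=O)O1` gives > 100000 nM, which is also a limit. Compound 2 therefore stands on (the limit of > 100000 nM in this assay, at which 2 of the 2 values shown sit), and no true number is available for either compound.

Compound 3 `CCCC(=O)OC[C@@H]1C=C[C@H](n2cc(F)c(N)nc2=O)O1` has not yet been measured. It differs from compound 2 in one place: ethyl in place of hydrogen on a saturated chain carbon bound to a carbonyl carbon. This is ethyl in place of hydrogen on a saturated chain carbon bound to a carbonyl carbon, which turns acetoxy into (propylcarbonyl)oxy.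

Going by the values given here, the only close guide is compound 2 at > 100000 nM, so no change beyond the usual scatter is expected, in either direction, and another limit is likely. The estimated step is a number no higher from compound 2 to compound 3 (the limit leaves the size open). Compound 3 is expected at 100000 nM, with an estimated range from 30000 nM to 300000 nM.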

Compound 3, half-maximal inhibitory concentration: > 100000 nM
Compound 3: only a limit was reported; the forecaster's own chance of this, stated with the estimate: 75%; the middle value sits exactly at the limit.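

For the compounds shown here, compound 2 and compound 3 are both reported only as limits, not as numbers, so no step between them can be read. The compounds shown leave open what true value any of them has in this assay, and whether (propylcarbonyl)oxy in place of acetoxy changes anything: the limit of > 100000 nM in this assay, at which 3 of the 3 values shown sit.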